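This account rests on a few compounds, and the source may have more. Where it says the series, first, only, none or still open, it means among the compounds named here.

Of the compounds shown here, three that share one core have been tested in a functional assay on HepG2 cells (Homo sapiens) for antiproliferative activity, read by CCK-8 assay, with a stated time of 72 h; a higher number here means a weaker inhibitor, a lower number a stronger inhibitor. Compound 1 `Cc1ccc(C(=O)Nc2cccc(-c3oc4cc(-c5ccc(F)cc5)ccc4c(=O)c3O)c2)cc1` gives 2320 nM in this assay, compound 2 `Cc1ccccc1C(=O)Nc1cccc(-c2oc3cc(-c4ccc(F)cc4)ccc3c(=O)c2O)c1` gives 19400 nM, and compound 3 `COc1ccc(C(=O)Nc2cccc(-c3oc4cc(-c5ccc(F)cc5)ccc4c(=O)c3O)c2)c(F)c1` gives 45300 nM. Compound 3 stands at the highest number of the three and is thus the weakest inhibitor here; the nearest step is a 2.3-fold higher number from compound 2 to compound 3 (0.37 log units; beyond the scatter), and the furthest is a 20-fold higher number from compound 1 to compound 3 (1.29 log units; beyond the scatter). The step of an 8.4-fold higher number from compound 1 to compound 2 (0.92 log units; beyond the scatter) shows that replacing 4-methylphenyl with 2-methylphenyl on the carbonyl carbon also weakens inhibition.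

Compound 4 `N#Cc1ccc(C(=O)Nc2cccc(-c3oc4cc(-c5ccc(F)cc5)ccc4c(=O)c3O)c2)cc1` has not yet been measured. It differs from compound 3 in one place: 4-cyanophenyl in place of 2-fluoro-4-methoxyphenyl on a carbonyl carbon. The 4-cyanophenyl that enters resembles the 4-methylphenyl of compound 1 more than the 2-methylphenyl of compound 2 or the 2-fluoro-4-methoxyphenyl of compound 3. Among the compounds with values here, the steps that bear on this are a 20-fold higher number from compound 1 to compound 3 (1.29 log units; beyond the scatter) and an 8.4-fold higher number from compound 1 to compound 2 (0.92 log units; beyond the scatter), both of which ran toward higher numbers when the 4-methylphenyl was exchanged; going back toward a ring of that kind points to a lower number for compound 4. Within the data shown here, no measured pair contains a nitrile, so the size is uncertain. The expected step is a 13-fold lower number from compound 3 to compound 4 (1.11 log units; beyond the scatter), beyond the scatter. Compound 4 is therefore estimated at 3500 nM in this assay, with a range from 1000 nM to 15000 nM.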

Compound 4, half-maximal inhibitory concentration: 7110 nM
Beside the measured number, compound 4's estimate is 2.0-fold (0.31 log units) below it; low and high end bracket the measured number.
By their numbers in this assay, from the lowest: compound 1; then compound 4; then compound 2; then compound 3.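

Within the data shown here, compound 4 gives a first look at a different group in the ring position held by the methyl of compound 1, and in this assay the exchange of cyano for methyl on an aromatic carbon comes at a cost, with a 3.1-fold higher number from compound 1 to compound 4 (0.49 log units; beyond the scatter) as the step. That ring still does better than the two others on the carbonyl carbon, as a 2.7-fold lower number from compound 2 to compound 4 (0.44 log units; beyond the scatter) and a 6.4-fold lower number from compound 3 to compound 4 (0.80 log units; beyond the scatter) show, so all four compounds now fit one order: the rings named with only a 4-substituent, 4-methylphenyl and 4-cyanophenyl, give lower numbers than 2-methylphenyl and 2-fluoro-4-methoxyphenyl, and compound 1 remains the strongest inhibitor of the four. Nothing available here explains why these rings differ in this way.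

Still open, from the compounds shown here alone, is whether an amine, a carboxylic acid or a longer chain in place of the methyl of compound 1 would come closer to compound 1 or fall further from it. The fluoro and the methoxy of 2-fluoro-4-methoxyphenyl also arrive together in compound 3, which leaves what each one contributes alone unknown.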